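A few compounds are considered here, and "the series" means these few. Any claim that something is new, unique, unknown or untested is made for them only; others in the source may bear on it.

In a functional assay on DU-145 cells (Homo sapiens) for antiproliferative activity, read by sulforhodamine B assay, with a stated time of 72 h (on this read-out lower numbers stand for stronger inhibition of growth and higher numbers for weaker inhibition of growth), three compounds have been measured so far. Compound 1 `Cc1cc(=O)oc2cc(SCc3cccc(C(F)(F)F)c3)ccc12` carries a trifluoromethyl group on a six-membered aromatic ring of carbon only. Compound 2 `Cc1cc(=O)oc2cc(SCc3cccc(C#N)c3)ccc12` differs from it in one place: cyano in place of trifluoromethyl on an aromatic carbon. In this assay compound 1 gives > 28500 nM, which is a limit of the assay and not a number. In this assay compound 2 gives > 32500 nM, again a limit and not a number. The step that the two limits leave unreadable from compound 1 to compound 2 is therefore unreadable, as the limit of > 28500 nM in this assay, at which 1 of the 3 values shown sits, and the limit of > 32500 nM in this assay, at which 1 of the 3 values shown sits, show both ends sitting at a limit.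

Compound 3 `CCc1cc(=O)c2ccc(OCc3cccc(C(F)(F)F)c3)c(C)c2o1` rests on a different core; the difference between the core of compound 1 and the core of compound 3 is not broken down here. In this assay compound 3 gives > 27600 nM, which is a limit and not a number, as the limit of > 27600 nM in this assay, at which 1 of the 3 values shown sits, shows.

Compound 4 `CCc1cc(=O)c2ccc(OCc3cccc(C#N)c3)c(C)c2o1` has not been measured. It differs from compound 3 in one place: cyano in place of trifluoromethyl on an aromatic carbon. The place of this change is the same word for word as in the change from compound 1 to compound 2, so the two are the same change. With every measured compound at a limit, the step from compound 3 to compound 4 is expected to be about a step that the limit leaves unreadable from compound 3 to compound 4, resting on compound 3 at > 27600 nM and on the unreadable step that the two limits leave unreadable from compound 1 to compound 2. For compound 4 the estimate in this assay is 30000 nM, from 15000 nM to 60000 nM, most likely reported only as a limit.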

Compound 4, concentration for 50% growth inhibition: > 31300 nM
Compound 4 was reported as a limit; the forecaster's own chance of this, stated with the estimate: 85%; middle value at least 1.0-fold (0.01 log units) away from the limit.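

In this assay compound 4 gives > 31300 nM, which is a limit of the assay and not a number. Compound 3 also sits at a limit, so the step between compound 3 and compound 4 cannot be read. The compounds shown leave open how strongly any of them inhibits growth, and whether cyano in place of trifluoromethyl changes that on either core.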